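Swapping the dichlorophenoxy arm for a fluorophenoxy arm

This account rests on a few compounds, and the source may have more. Where it says the series, first, only, none or still open, it means among the compounds named here.

Measured compounds:
- Compound 1, `Nc1cc(N)c2nc(-c3ccccc3)c(Oc3ccc(Cl)c(Cl)c3)nc2c1`: < 100000 nM
- Compound 2, `Nc1cc(N)c2nc(-c3ccccc3)c(NCc3ccc(Cl)c(Cl)c3)nc2c1`: 33100 nM
- Compound 3, `CCOC(=O)[C@H](CCC(=O)O)NC(=O)c1ccc(Sc2nc3cc(N)cc(N)c3nc2-c2ccccc2)cc1`: < 100000 nM

All three were tested in a functional assay on DU-145 cells (Homo sapiens) for inhibition, read by sulforhodamine B assay, with a stated time of 48 h; a higher number here means a weaker inhibitor of growth, a lower number a stronger inhibitor of growth. For compound 1 the reported result is only a limit of the assay, < 100000 nM, not a number. For compound 3 the result is likewise only a limit, < 100000 nM. Within the data shown here, compound 2 is the one member of the set with a numeric value, 33100 nM, and this value is far from strong growth inhibition. Taken together, the limit of < 100000 nM in this assay, at which 2 of the 3 values shown sit, shows how weakly this series acts on the cells; compound 1 itself stands at that limit, so its true position could be anywhere at or above the weak end of what the assay can report.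

The unmeasured compound 4, `Nc1cc(N)c2nc(-c3ccccc3)c(Oc3ccc(F)cc3)nc2c1`, keeps the shared core of compound 1 and changes only the aryl ether: 4-fluorophenyl in place of 3,4-dichlorophenyl on an oxygen on an aromatic ring. With no measured step of this kind in the set, the expectation for the step from compound 1 to compound 4 must rest on the overall weakness of compounds 1, 2 and 3 in this assay. The step that the limit leaves unreadable from compound 1 to compound 4 is expected to be small, most likely within the scatter, and a limit rather than a number is a real possibility. Compound 4 is estimated at 50000 nM, with a range from 15000 nM to 100000 nM.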

Compound 4, concentration for total growth inhibition: 87100 nM
Estimate against measurement, compound 4: 1.7-fold (0.24 log units) below, and the stated range covers the measured number.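

Compound 1 has only a limit of the assay, < 100000 nM, not a number. The step from compound 1 to compound 4 therefore cannot be read. The compounds shown leave open whether 4-fluorophenyl on the shared core inhibits cell growth any more or less strongly than 3,4-dichlorophenyl does.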